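Trading a Chlorophenyl for a Thiophene Ring

A few compounds are considered here, and "the series" means these few. Any claim that something is new, unique, unknown or untested is made for them only; others in the source may bear on it.

Measured compounds:
compound 1 `COc1ccc(-c2nc(CNc3ccc(C(=O)NO)cc3)n(-c3ccccc3)n2)cc1`: 77.6%
compound 2 `O=C(NO)c1ccc(NCc2nc(-c3cccc(Cl)c3)nn2-c2ccccc2)cc1`: 61.2%
compound 3 `O=C(NO)c1ccc(NCc2nc(-c3ccc(Cl)cc3)nn2-c2ccccc2)cc1`: 67.2%

Three compounds share one core and differ only in the ring carried on one carbon of that core. In an assay on Sf9 cells for inhibition of protein deacetylase HDAC6 (Homo sapiens), read by fluorescence, with a stated time of 40 min, tested at 100 nM (a higher number here means more inhibition at the concentration tested (going by the name of the read-out), a lower number less inhibition), compound 3 stands second highest of the three. Its nearest neighbour is compound 2, with a number 6 percentage points higher from compound 2 to compound 3 (within the scatter), a gap within the scatter, so the two cannot be ranked. The furthest is compound 1, with a number 10.4 percentage points lower from compound 1 to compound 3 (beyond the scatter).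

Compound 4 `O=C(NO)c1ccc(NCc2nc(-c3ccsc3)nn2-c2ccccc2)cc1` has not yet been measured. It differs from compound 3 in one place: thiophen-3-yl in place of 4-chlorophenyl on an aromatic carbon

Among the compounds with values here, no measured step exchanges this six-membered ring for a five-membered one. The steps that do vary the ring on this carbon are a number 16.4 percentage points lower from compound 1 to compound 2 (beyond the scatter), a number 10.4 percentage points lower from compound 1 to compound 3 (beyond the scatter) and a number 6 percentage points higher from compound 2 to compound 3 (within the scatter), all modest or within the scatter. A change of similar size is therefore expected here, in either direction but more likely slightly downward, as the step of a number 5.2 percentage points lower from compound 3 to compound 4 (within the scatter) is estimated. For compound 4 the expected value is 62%, with a range from 45% to 78%.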

Compound 4, a percentage reported as inhibition, at one concentration (the size of the read-out at that concentration, not a potency): 53.4%
Estimate against measurement, compound 4: 8.6 percentage points above; the measured number falls inside the stated range.
By their numbers in this assay, from the lowest: compounds 4, 2 and 3 (each within the scatter of the next, the first and the last beyond it); then compound 1.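

The thiophen-3-yl group is the only five-membered ring shown on this carbon, and in this assay exchanging 4-chlorophenyl for it gives a number 13.8 percentage points lower from compound 3 to compound 4 (beyond the scatter), so this ring exchange has a measurable effect. The comparison with the other chlorinated ring is less firm: a number 7.8 percentage points lower from compound 2 to compound 4 (within the scatter), which means that thiophen-3-yl and 3-chlorophenyl cannot be ranked. The largest gap among the four compounds is a number 24.2 percentage points lower from compound 1 to compound 4 (beyond the scatter), and the 4-methoxyphenyl of compound 1 stays beyond the scatter from all three other rings shown here.

No available evidence explains why these rings give different numbers. On these data alone, it also remains open how this position would respond to a methoxy group on the thiophen-3-yl ring, or to an amine or a carboxylic acid on the ring at this carbon.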